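A few compounds are considered here, and "the series" means these few. Any claim that something is new, unique, unknown or untested is made for them only; others in the source may bear on it.

In a functional assay on MCF7 cells (Homo sapiens) for cytotoxicity, read by MTT assay, with a stated time of 72 h (a lower number here means a stronger inhibitor, a higher number a weaker inhibitor), two compounds have been measured so far. Compound 1 `O=C1c2c[n+]([O-])c3ccccc3c2C(=O)c2c1c1ccccc1n2Cc1cn([C@H]2O[C@H](CO)[C@@H](O)[C@H]2O)nn1` gives 1490 nM, and compound 2 `O=C1c2c[n+]([O-])c3ccccc3c2C(=O)c2c1c1ccccc1n2Cc1cn(CC(O)CO)nn1` gives 1110 nM. Compound 2 has the lowest number of the pair, but the two values cannot be told apart within the usual scatter. Compound 3 `CC1(C)OC[C@@H](Cn2cc(Cn3c4c(c5ccccc53)C(=O)c3c[n+]([O-])c5ccccc5c3C4=O)nn2)O1` keeps the core of compound 2 and alters its side group: 2,2-dimethyl-1,3-dioxolan-4-yl in place of 1,2-dihydroxyethyl on a saturated chain carbon bound to an aromatic nitrogen. Going by the values given here, the only measured step that bears on this change is a 1.3-fold lower number from compound 1 to compound 2 (0.13 log units; within the scatter), which also exchanges a group on an aromatic nitrogen. Among the compounds with values here, that single step is a weak guide, since both measured side groups carry free hydroxy groups and no measured compound lacks them. No step beyond the scatter is therefore expected in this assay, though with wide uncertainty. The expected step is a 1.1-fold higher number from compound 2 to compound 3 (0.03 log units; within the scatter). For compound 3 the estimated value is 1200 nM, with an expected range of 500 nM to 3000 nM.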

Compound 3, half-maximal inhibitory concentration: > 1000 nM
Compound 3: only a limit was reported; the forecaster's own chance of this, stated with the estimate: 3%; the middle value does not contradict the limit.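

In this assay, compound 3 is reported only as a limit, > 1000 nM. The steps to compound 3 from compound 1 and from compound 2 therefore cannot be read. Going by these compounds, whether replacing 1,2-dihydroxyethyl with 2,2-dimethyl-1,3-dioxolan-4-yl changes the number at all remains open.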